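A few compounds are considered here, and "the series" means these few. Any claim that something is new, unique, unknown or untested is made for them only; others in the source may bear on it.

Measured compounds in a functional assay on SK-OV-3 cells (Homo sapiens) for antiproliferative activity, read by MTT assay, with a stated time of 48 h; a higher number here means a weaker inhibitor, a lower number a stronger inhibitor:
compound 1 `CCOc1ccc(-c2nc(NS(=O)(=O)c3ccc(OC)c(F)c3)sc2-c2cc(OC)c(OC)c(OC)c2)cc1`; compound 1 gives > 5000 nM, a limit of the assay.
compound 2 `CCOc1ccc(-c2nc(NS(=O)(=O)c3ccc(C)c(C)c3)sc2-c2cc(OC)c(OC)c(OC)c2)cc1`; compound 2 gives > 5000 nM, a limit of the assay.
compound 3 `CCOc1ccc(-c2nc(NS(=O)(=O)c3ccccc3C(F)(F)F)sc2-c2cc(OC)c(OC)c(OC)c2)cc1`; compound 3 gives > 5000 nM, a limit of the assay.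

Compound 3 thus stands at the limit, not at a number. All three measured values sit at that same limit (the limit of > 5000 nM in this assay, at which 3 of the 3 values shown sit). The three steps among the measured compounds, a step that the two limits leave unreadable from compound 1 to compound 2, a step that the two limits leave unreadable from compound 1 to compound 3 and a step that the two limits leave unreadable from compound 2 to compound 3, are unreadable in size, as both ends of each are limits.

Compound 4 `CCOc1ccc(-c2nc(NS(=O)(=O)c3ccc([N+](=O)[O-])cc3OC)sc2-c2cc(OC)c(OC)c(OC)c2)cc1` differs from compound 3 by 2-methoxy-4-nitrophenyl in place of 2-(trifluoromethyl)phenyl on a sulfonyl sulfur. The change sits on the sulfonyl sulfur, the same place varied in all three measured steps, none of which gave a readable size or direction. Within the data shown here, no measured step therefore bears on the size of the step to compound 4; the expectation rests only on (the limit of > 5000 nM in this assay, at which 3 of the 3 values shown sit). Compound 4 is expected to give 8000 nM, within 3000 nM to 30000 nM, most likely again reported as a limit in this assay. The estimated step from compound 3 to compound 4 is a step that the limit leaves unreadable from compound 3 to compound 4, with nothing beyond the scatter expected.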

Compound 4, half-maximal inhibitory concentration: > 5000 nM
Compound 4: only a limit was reported (the forecaster's own chance of this, stated with the estimate: 80%); the middle value does not contradict the limit.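

Among these compounds, compound 4 gives > 5000 nM as a limit and not a number, so no step from compound 1, compound 2 or compound 3 to compound 4 can be read. The compounds shown leave open whether any group on the sulfonyl sulfur gives a number rather than a limit.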